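Replacing (pyridin-2-yl)methyl with 3-(trifluoromethyl)phenyl in compound 2

The compounds below may be only part of what the source reports. "The series", "measured", "known", "first", "only" and "open" are said of these compounds alone.

Measured compounds:
- compound 1 `CN(C[C@H]1Cc2c(cccc2N2CCN(C3COC3)CC2)CN1)[C@H]1CCCc2cccnc21`: 50.8%
- compound 2 `CN(C[C@H]1Cc2c(cccc2N2CCN(Cc3ccccn3)CC2)CN1)[C@H]1CCCc2cccnc21`: 40.4%

For the measured compounds named here, in an ADME assay on microsomes from liver (Mus musculus) for metabolic stability, read by LC-MS, with a stated time of 10 min (a lower number here means that less of the compound is left, a higher number that more of the compound is left), compound 2 gives 40.4%, the lowest of the two numbers measured so far, and compound 1 is the only neighbour it can be compared with.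

Compound 3 `CN(C[C@H]1Cc2c(cccc2N2CCN(c3cccc(C(F)(F)F)c3)CC2)CN1)[C@H]1CCCc2cccnc21` keeps the shared core and changes the group on an amine nitrogen in a ring: 3-(trifluoromethyl)phenyl in place of (pyridin-2-yl)methyl on an amine nitrogen in a ring. In words, 3-(trifluoromethyl)phenyl stands in place of (pyridin-2-yl)methyl.

Going by the values given here, only one measured step bears on this, and it sits at the same place. It is a number 10.4 percentage points lower from compound 1 to compound 2 (beyond the scatter), with (pyridin-2-yl)methyl in place of oxetan-3-yl. This single step shows that a swap here can move the number by a modest amount. It involves a different pair of groups, however, so it is only a weak guide to direction. A further modest fall is the best guess, and a result close to compound 2 would be no surprise.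

The expected change is a number 7.4 percentage points lower from compound 2 to compound 3 (within the scatter). For compound 3 the estimated value is 33%, with an expected range from 14% to 52%.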

Compound 3, percent of the compound remaining: 72.3%
The estimate for compound 3 lay 39.3 percentage points below the measured number, outside the stated range (above it).
By their numbers in this assay, from the lowest: compound 2; then compound 1; then compound 3.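

In this assay, the group on this ring nitrogen can push the number up as well as down: the result is a number 31.9 percentage points higher from compound 2 to compound 3 (beyond the scatter), a large step, and a number 21.5 percentage points higher from compound 1 to compound 3 (beyond the scatter), a modest one. The only earlier step at this position was a modest fall, so this is the first sign that the position has room for clear gains, and that 3-(trifluoromethyl)phenyl sits above both (pyridin-2-yl)methyl and oxetan-3-yl among the three groups shown. The counted differences are that the entering group has more heavy atoms and no hydrogen-bond acceptor, but no measurement at hand links either difference to the rise.

The compounds shown cannot separate the contribution of the phenyl ring from that of the trifluoromethyl group, so it remains open whether a plain phenyl, or a phenyl carrying a chlorine or a nitrile, would give a similar number. As far as these compounds go, it is also open how a carbonyl-linked group such as an amide on this nitrogen would compare, and whether the gain holds in liver microsomes from other species.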